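The source may hold more compounds than are shown below. What is called first, only, known or untested is meant among the compounds shown, and "the series" means these compounds.

Of the compounds shown here, two built on the same core have been measured. In a functional assay on HCT-116 cells (Homo sapiens) for cytotoxicity, read by MTT assay, with a stated time of 48 h (a lower number here means a stronger inhibitor, a higher number a weaker inhibitor), compound 2 `O=C(/C=C/c1ccc2c(c1)B(O)OC2)c1ccc(Br)cc1` gives 9900 nM. Compound 1 `Cn1cccc1C(=O)/C=C/c1ccc2c(c1)B(O)OC2` reaches only a limit in this assay, namely > 100000 nM (the limit of > 100000 nM in this assay, at which 1 of the 2 values shown sits). Going by the values given here, the single step between measured compounds, an at least 10-fold lower number from compound 1 to compound 2 (1.00 log units; beyond the scatter), exchanges the group attached to the carbonyl carbon. Compound 2 therefore holds the only actual number shown, the other value being a limit. Compound 3 `Cc1ccc(C(=O)/C=C/c2ccc3c(c2)B(O)OC3)cc1` differs from compound 2 by methyl in place of bromo on an aromatic carbon. Among the compounds with values here, no measured step touches this position: the only step, an at least 10-fold lower number from compound 1 to compound 2 (1.00 log units; beyond the scatter), concerns a different part of the molecule and replaced a whole ring, so it gives no direct guide to a change on the aromatic carbon. With nothing to suggest a shift, the step of a 1.2-fold higher number from compound 2 to compound 3 (0.08 log units; within the scatter) is expected to stay within the usual scatter. Compound 3 is accordingly estimated at 12000 nM, with a range from 4000 nM to 40000 nM.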

Compound 3, half-maximal inhibitory concentration: 10500 nM
Compound 3: middle estimate off by 1.1-fold (0.06 log units), on the high side, and the stated range covers the measured number.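

In this assay, a 1.1-fold higher number from compound 2 to compound 3 (0.03 log units; within the scatter) shows that bromo and methyl on this aromatic carbon, para to a large group, cannot be told apart. A second six-membered aromatic ring now also stands against the 1-methyl-1H-pyrrol-2-yl compound, with an at least 9.5-fold lower number from compound 1 to compound 3 (0.97 log units; beyond the scatter), so the difference first seen with 4-bromophenyl does not depend on bromine and holds for 4-methylphenyl as well. The size of that step remains a bound rather than a measured distance, since the value of compound 1 is a limit: the limit of > 100000 nM in this assay, at which 1 of the 3 values shown sits.

The compounds shown leave open whether an amine, a carboxylic acid or a longer chain on this carbon would leave the number unchanged. They also leave open how a plain phenyl, with only hydrogen there, would compare with compound 2 and compound 3.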